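Allyl to ethyl on the acetophenone core

The compounds below may be only part of what the source reports. "The series", "measured", "known", "first", "only" and "open" are said of these compounds alone.

Working notes. The series is tested in an assay on isolated protein for binding affinity to leukotriene B4 receptor 1 (Homo sapiens), tested at 1 uM; a lower number here means less inhibition, a higher number more inhibition at the concentration tested (going by the name of the read-out). Among the measured compounds shown here, compound 1 `C=CCc1cc(C(C)=O)c(O)cc1OCc1cccc(C#N)c1` gives 58% in this assay, the higher of the two numbers so far. Compound 2 `C=CCc1cc(C(C)=O)c(O)cc1OCc1ccc(C#N)cc1` gives 28% in this assay, a gap to compound 1 beyond the scatter. Compound 3 `CCc1cc(C(C)=O)c(O)cc1OCc1cccc(C#N)c1` is not yet measured. The change from compound 1 to compound 3 is methyl in place of vinyl on a saturated chain carbon bound to an aromatic carbon. For the measured compounds named here, no measured pair shows this step, so the expected step of a number 8 percentage points lower from compound 1 to compound 3 (within the scatter) is a small loss, near the scatter. Compound 3 is estimated at 50%, within 30% to 70%.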

Compound 3, a percentage reported as inhibition, at one concentration (the size of the read-out at that concentration, not a potency): 61%
Beside the measured number, compound 3's estimate is 11 percentage points below it, and the stated range covers the measured number.
By their numbers in this assay, from the lowest: compound 2; then compounds 1 and 3 (each within the scatter of the next).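

Going from allyl to ethyl in this assay gives a number 3 percentage points higher from compound 1 to compound 3 (within the scatter). At this place on the shared core, the read-out therefore does not separate the two chains, and the double bond of the allyl group can go without a difference beyond the scatter, at least in this single pair. Nothing on hand explains why the two chains read alike.

From the compounds shown here alone, whether a propyl chain, a lone methyl or an amine at this place would hold the read-out remains open. So does whether the same step holds on the core of compound 2.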